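A few compounds are considered here, and "the series" means these few. Any claim that something is new, unique, unknown or untested is made for them only; others in the source may bear on it.

In a functional assay on HCT-116 cells (Homo sapiens) for antiproliferative activity, read by MTT assay, with a stated time of 48 h (a higher number here means a weaker inhibitor, a lower number a stronger inhibitor), compound 3 `CCCCCCC(CCO)n1cnc2c(OC)ncnc21` gives > 50000 nM, which is a limit and not a number. Compound 1 `CCCCCC(CCO)n1cnc2c(N(C)C)ncnc21`, which carries dimethylamino, gives > 50000 nM, also a limit. Both sit at the limit of > 50000 nM in this assay, at which 2 of the 3 values shown sit. Compound 2 `CCCCCCC(CCO)n1cnc2c(Cl)ncnc21`, with chloro, gives a true number, 11900 nM. For the measured compounds named here, the one measured step on this aromatic carbon is an at least 4.2-fold higher number from compound 2 to compound 3 (0.62 log units; beyond the scatter). Compound 4 `CCCCCCC(CCO)n1cnc2c(N(C)C)ncnc21` has dimethylamino in place of methoxy on that aromatic carbon (dimethylamino in place of methoxy on an aromatic carbon). This change does not bring chloro back, and compound 1 already shows dimethylamino at the limit, so no step beyond the scatter is expected in this assay. The expected change is a number no higher from compound 3 to compound 4 (the limit leaves the size open). For compound 4 the estimate is 50000 nM, with an expected range of 20000 nM to 120000 nM.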

Compound 4, half-maximal inhibitory concentration: > 50000 nM
Compound 4: a limit, no number; the forecaster's own chance of this, stated with the estimate: 75%; the middle value lies on the limit itself.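

In this assay, dimethylamino in place of chloro on this aromatic carbon gives an at least 4.2-fold higher number from compound 2 to compound 4 (0.62 log units; beyond the scatter), so this second replacement for chloro on the same chain also loses the measurable effect, as methoxy did. The result for compound 4 is a limit, and among the compounds shown only compound 2, with chloro, keeps a true number: the limit of > 50000 nM in this assay, at which 3 of the 4 values shown sit. The steps to compound 4 from compound 3 and from compound 1 cannot be read. As far as these compounds go, whether bromo or a primary amine on this carbon would give a true number remains open.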